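Changing the halogenated phenyl on the amide carbonyl

The compounds below may be only part of what the source reports. "The series", "measured", "known", "first", "only" and "open" are said of these compounds alone.

Three compounds sharing one core have been measured in an assay on isolated protein for inhibition of liver carboxylesterase 1 (Homo sapiens), read by spectrophotometry; on this read-out lower numbers stand for stronger inhibition and higher numbers for weaker inhibition:

Compound 1, `O=C(C(=O)c1ccccn1)c1cccc(NC(=O)c2ccc(Cl)cc2Cl)c1`: 279 nM
Compound 2, `O=C(Nc1cccc(C(=O)C(=O)c2ccccn2)c1)c1ccc(F)c(F)c1`: 1240 nM
Compound 3, `O=C(Nc1cccc(C(=O)C(=O)c2ccccn2)c1)c1cccc(Cl)c1`: 756 nM

Compound 3 sits second highest of the three numbers. Its nearest neighbour is compound 2, and these two lie within the scatter of each other, as the step of a 1.6-fold lower number from compound 2 to compound 3 (0.21 log units; within the scatter) shows. Its furthest neighbour is compound 1, reached by the step of a 2.7-fold higher number from compound 1 to compound 3 (0.43 log units; beyond the scatter), which runs beyond the scatter. The third step, a 4.4-fold higher number from compound 1 to compound 2 (0.65 log units; beyond the scatter), also runs beyond the scatter.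

Compound 4, `O=C(Nc1cccc(C(=O)C(=O)c2ccccn2)c1)c1ccc(F)cc1`, has not yet been measured. It differs from compound 3 in one place: 4-fluorophenyl in place of 3-chlorophenyl on a carbonyl carbon. For the measured compounds named here, no measured step matches this exact change. The closest evidence is the step of a 1.6-fold lower number from compound 2 to compound 3 (0.21 log units; within the scatter), where one halogen pattern on that phenyl was traded for another and the number barely moved, and the step of a 2.7-fold higher number from compound 1 to compound 3 (0.43 log units; beyond the scatter), where fewer chlorines went with a higher number. Taken together, these suggest at most a modest shift in this assay for compound 4, with a higher number somewhat more likely than a lower one.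

Compound 4 is therefore expected to give about 1000 nM, within a range from 400 nM to 2500 nM, an estimated step of a 1.3-fold higher number from compound 3 to compound 4 (0.12 log units; within the scatter).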

Compound 4, inhibition constant: 381 nM
Compound 4: middle estimate off by 2.6-fold (0.42 log units), on the high side, and the stated range ends above it.
By their numbers in this assay, from the lowest: compounds 1, 4, 3 and 2 (each within the scatter of the next, the first and the last beyond it).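

In this assay, replacing 3-chlorophenyl with 4-fluorophenyl on the carbonyl carbon gives a 2.0-fold lower number from compound 3 to compound 4 (0.30 log units; within the scatter), so moving from one single-halogen ring to the other cannot be read as a real change. For the compounds shown here, the only new step beyond the scatter comes from the smallest edit, hydrogen in place of fluoro on an aromatic carbon, which gives a 3.3-fold lower number from compound 2 to compound 4 (0.51 log units; beyond the scatter) and shows that one fluoro on this phenyl can make a measurable difference to the number. The last new step, a 1.4-fold higher number from compound 1 to compound 4 (0.14 log units; within the scatter), means that a ring carrying a single fluoro and no chlorine cannot be told apart from the 2,4-dichlorophenyl ring, so the earlier link between fewer chlorines and a higher number does not extend to this ring.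

Nothing available here explains why the extra fluoro goes with a higher number. From the compounds shown here alone, it also remains open how a 4-chlorophenyl, a 4-methoxyphenyl or a 4-aminophenyl on the same carbonyl carbon would read in this assay, and so whether the halogen itself matters or any small group would serve there.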